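Replacing Cyclopropyl with Cyano in Compound 2

The source may hold more compounds than are shown below. What is called first, only, known or untested is meant among the compounds shown, and "the series" means these compounds.

Of the compounds shown here, two have been tested so far in an in vitro ADME assay on microsomes from liver (Rattus norvegicus) for metabolic stability; a higher number here means faster removal of the compound, a lower number slower removal. Compound 1 `CN(c1ccc(Cl)cc1)c1ccc(Nc2nccc(N)n2)cc1` gives > 399 mL.min-1.g-1, which is a limit of the assay and not a number. For the measured compounds named here, compound 2 `Nc1cncc(Nc2ccc(Oc3ccc(C4CC4)cc3)cc2)n1` gives 70 mL.min-1.g-1, the only exact number available, so it is the natural starting point.

Compound 3 `N#Cc1ccc(Oc2ccc(Nc3cncc(N)n3)cc2)cc1` has not yet been measured. It has cyano in place of cyclopropyl on an aromatic carbon, para to a large group (cyano in place of cyclopropyl on an aromatic carbon). The two measured compounds differ in more than one place, so they offer no direct guide to this change, and any forecast is tentative. A moderate move towards slower removal is expected, only modestly beyond the usual scatter. The estimated change is a 2.3-fold lower number from compound 2 to compound 3 (0.37 log units; beyond the scatter) in this assay. For compound 3 the estimate is 30 mL.min-1.g-1, with an expected range of 11 mL.min-1.g-1 to 80 mL.min-1.g-1.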

Compound 3, intrinsic clearance in microsomes: 216 mL.min-1.g-1
Compound 3: middle estimate off by 7.2-fold (0.86 log units), on the low side; the measured number lies above the stated range.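

For the compounds shown here, this is the first comparison in the set that changes only one place: in this assay, putting cyano in place of cyclopropyl gives a 3.1-fold higher number from compound 2 to compound 3 (0.49 log units; beyond the scatter). The group on this aromatic carbon, para to a large group, therefore matters for the read-out, and in this pair cyano goes with faster removal, not slower. Compound 1 stays outside any such comparison, as its reading is a limit of the assay and not a number: the limit of > 399 mL.min-1.g-1 in this assay, at which 1 of the 3 values shown sits.

A single pair cannot separate the loss of cyclopropyl from the arrival of cyano, and nothing shown gives a reason for the rise. As far as these compounds go, whether a methoxy group or an amine at this position would fall nearer compound 2 or compound 3 remains open.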